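This account rests on a few compounds, and the source may have more. Where it says the series, first, only, none or still open, it means among the compounds named here.

Of the compounds shown here, three with a shared core have been measured so far in a physicochemical assay for lipophilicity, at pH 7.4 (a higher number here means a more lipophilic compound, a lower number a more polar compound), on this question. Compound 1 `CCc1ccc(N(CC(C)C)S(=O)(=O)c2ccc3c(c2)C(=O)CC(C2CCN(S(=O)(=O)C4CCCC4)CC2)O3)cc1` gives 4.75 and compound 2 `CCc1ccc(N(CC(C)C)S(=O)(=O)c2ccc3c(c2)C(=O)CC(CC2CCOCC2)O3)cc1` gives 4.53 here, while compound 3 `CCc1ccc(N(CC(C)C)S(=O)(=O)c2ccc3c(c2)C(=O)CC(C2CCN(C(=O)OC(C)(C)C)CC2)O3)cc1` gives 5.1 as the highest of the three. Compound 4 `CCc1ccc(N(CC(C)C)S(=O)(=O)c2ccc3c(c2)C(=O)CC(C2CCNCC2)O3)cc1` awaits measurement and differs from compound 3 by one change, hydrogen in place of tert-butoxycarbonyl on an amine nitrogen in a ring. For the measured compounds named here, the only measured step that bears on this swaps one group on that nitrogen for another, and it is modest (a number 0.35 log units higher from compound 1 to compound 3 (beyond the scatter)). Going by the values given here, that step left a group in place, whereas here the group leaves without a replacement, and no measured compound has the bare nitrogen. A downward step much larger than that one is therefore expected (a number 2.00 log units lower from compound 3 to compound 4 (beyond the scatter)). For compound 4 the estimated value is 3.1 within a range of 2.3 to 3.9 in this assay once measured.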

Compound 4, distribution coefficient: 2.21
Compound 4: middle estimate off by 0.89 log units, on the high side; measured number below the stated range.
By their numbers in this assay, from the lowest: compound 4; then compounds 2 and 1 (each within the scatter of the next); then compound 3.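

In this assay, whether the ring nitrogen carries a group at all matters far more than which group it carries: losing tert-butoxycarbonyl gives a large drop (a number 2.89 log units lower from compound 3 to compound 4 (beyond the scatter)), and losing cyclopentylsulfonyl gives another (a number 2.54 log units lower from compound 1 to compound 4 (beyond the scatter)), both well beyond the modest swap of one group for the other (a number 0.35 log units higher from compound 1 to compound 3 (beyond the scatter)). The bare piperidine also falls far under the compound with (oxan-4-yl)methyl (a number 2.32 log units lower from compound 2 to compound 4 (beyond the scatter)). Nothing measured here explains the size of these drops.

Still open, on these data alone, is whether a small group on that nitrogen, such as methyl or acetyl, would bring the number close to compound 4 or close to compound 3.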